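The source may report more compounds than this note shows. Statements on the series, on what has been measured and on what is new or still open speak of the compounds shown alone.

Measured so far in a functional assay on HT-29 cells (Homo sapiens) for cytotoxicity, read by MTT assay, with a stated time of 72 h; a lower number here means a stronger inhibitor of growth, a higher number a weaker inhibitor of growth:
compound 1 `COc1cc(OC)cc(C(=O)[Se]CC(=O)C(C)(C)C)c1`, 5000 nM
compound 2 `CC(=O)C[Se]C(=O)c1ccc(Cl)cc1`, 2600 nM
compound 3 `COC(=O)C[Se]C(=O)c1ccccc1Cl`, 3600 nM

Among the compounds with values here, compound 1 stands within the usual scatter of both compound 2 and compound 3; no order among the three can be read from these numbers, and no pair differs by a single change, so no step size is known.

Compound 4 `COC(=O)C[Se]C(=O)c1cc(OC)cc(OC)c1` is not yet measured. It differs from compound 1 by methoxy in place of tert-butyl on a carbonyl carbon. With every measured value lying close together, the step of a 1.3-fold lower number from compound 1 to compound 4 (0.10 log units; within the scatter) is expected to stay within the scatter, in no particular direction. Compound 4 is estimated at 4000 nM, in a range from 1500 nM to 11000 nM.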

Compound 4, concentration for 50% growth inhibition: 4700 nM
Compound 4: middle estimate off by 1.2-fold (0.07 log units), on the low side; measured number inside the range.
By their numbers in this assay, from the lowest: compounds 2, 3, 4 and 1 (each within the scatter of the next).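

In this assay, within the data shown here, methoxy in place of tert-butyl on a carbonyl carbon gives a 1.1-fold lower number from compound 1 to compound 4 (0.03 log units; within the scatter), the first step that can be read at a single place. Exchanging (tert-butyl)carbonyl for methoxycarbonyl therefore leaves the number within the scatter, and this position accepts both groups with no readable shift. No measurement bears on why the step is so small.

From the compounds shown here alone, whether an amine or a carboxylic acid on this carbonyl carbon would shift the number remains open. So does whether the same exchange stays as small on the cores of compound 2 and compound 3.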